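Swapping fluoro for chloro on compound 3

The source may hold more compounds than are shown below. What is called first, only, known or untested is meant among the compounds shown, and "the series" means these compounds.

Measured in a functional assay on a cell-free system (Platelet, plasma, Homo sapiens) for inhibition; on this read-out lower numbers stand for stronger inhibition and higher numbers for weaker inhibition:
compound 1 `Cc1ccc(N(CCN2CCC(OCC(=O)O)CC2)C(=O)c2ccc(F)cc2)cc1`: 970 nM
compound 2 `COc1ccc(C(=O)N(CCN2CCC(OCC(=O)O)CC2)c2ccc(C)cc2)cc1`: 1200 nM
compound 3 `Cc1ccc(N(CCN2CCC(OCC(=O)O)CC2)C(=O)c2cccc(F)c2)cc1`: 160 nM

Compound 3 has the lowest number of the three, making it the strongest inhibitor so far. Compound 4 `Cc1ccc(N(CCN2CCC(OCC(=O)O)CC2)C(=O)c2cccc(Cl)c2)cc1` carries chloro in place of fluoro on an aromatic carbon. Going by the values given here, no measured step makes this exact swap. Putting 3-fluorophenyl in place of 4-fluorophenyl gave a 6.1-fold lower number from compound 1 to compound 3 (0.78 log units; beyond the scatter), and 3-fluorophenyl in place of 4-methoxyphenyl gave a 7.5-fold lower number from compound 2 to compound 3 (0.88 log units; beyond the scatter). Both of these changed the place of the group. Methoxy in place of fluoro kept the place, as this swap does, and gave a 1.2-fold higher number from compound 1 to compound 2 (0.09 log units; within the scatter). The expected change is therefore small, with no clear direction: a 1.1-fold lower number from compound 3 to compound 4 (0.03 log units; within the scatter). For compound 4 the estimated value is 150 nM, with an expected range from 50 nM to 450 nM.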

Compound 4, half-maximal inhibitory concentration: 100 nM
Compound 4: middle estimate off by 1.5-fold (0.18 log units), on the high side; low and high end bracket the measured number.
By their numbers in this assay, from the lowest: compounds 4 and 3 (each within the scatter of the next); then compounds 1 and 2 (each within the scatter of the next).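

In this assay, going by these compounds alone, the first direct exchange of one halogen for another at this place gives a 1.6-fold lower number from compound 3 to compound 4 (0.20 log units; within the scatter), so chloro and fluoro cannot be told apart here. The advantage seen with 3-fluorophenyl also holds for 3-chlorophenyl, with a 9.7-fold lower number from compound 1 to compound 4 (0.99 log units; beyond the scatter) and a 12-fold lower number from compound 2 to compound 4 (1.08 log units; beyond the scatter). Both comparisons are against groups substituted at a different place on the ring, so within these compounds the place matters more than the choice of halogen.

From the compounds shown here alone, whether a nitrile or methoxy at this same place would give similar numbers remains open. No supporting measurement is available to explain these differences.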